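The source may hold more compounds than are shown below. What is called first, only, known or untested is meant among the compounds shown, and "the series" means these compounds.

Compound 1 `Cc1ccc(S(=O)(=O)/C(=C/c2sccc2C)C(=O)c2ccc(Cl)cc2)cc1` is a sulfone-bearing enone in which an aryl group hangs from the double bond. In a functional assay on DU-145 cells (Homo sapiens) for inhibition, read by trypan blue exclusion, with a stated time of 96 h (on this read-out higher numbers stand for weaker inhibition of growth and lower numbers for stronger inhibition of growth), compound 1 gives 10000 nM. For the measured compounds named here, its only measured neighbour is compound 2 `Cc1ccsc1/C=C(\C(=O)c1ccc(Cl)cc1)S(=O)(=O)Cc1ccc(Cl)cc1`, which in this assay gives 25000 nM; the one step known so far, a 2.5-fold higher number from compound 1 to compound 2 (0.40 log units; beyond the scatter), changes the group on the sulfonyl sulfur, so compound 1 stands with the lower of the two numbers seen.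

Compound 3 `Cc1ccc(S(=O)(=O)/C(=C/c2ccc(O)c([N+](=O)[O-])c2)C(=O)c2ccc(Cl)cc2)cc1` differs from compound 1 at a different position: 4-hydroxy-3-nitrophenyl in place of 3-methylthiophen-2-yl on a double-bonded chain carbon bound to a double-bonded chain carbon. Going by the values given here, no measured step touches this part of the molecule, and the step from compound 1 to compound 2 cannot speak to a swap of the aryl group on the double bond. With nothing to set direction, the outlook is that the change leaves the number where compound 1 stands, within the usual spread, and any shift beyond it is as likely one way as the other.

On that footing compound 3 is expected to show a 1.1-fold lower number from compound 1 to compound 3 (0.05 log units; within the scatter) in this assay, which means an estimated 9000 nM with a range from 2500 nM to 35000 nM.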

Compound 3, concentration for 50% growth inhibition: 25000 nM
Compound 3: middle estimate off by 2.8-fold (0.44 log units), on the low side; low and high end bracket the measured number.
By their numbers in this assay, from the lowest: compound 1; then compounds 2 and 3 (each within the scatter of the next).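

Moving from 3-methylthiophen-2-yl to 4-hydroxy-3-nitrophenyl on a double-bonded chain carbon bound to a double-bonded chain carbon brings a 2.5-fold higher number from compound 1 to compound 3 (0.40 log units; beyond the scatter) in this assay and so points towards weaker inhibition of growth. This modest step shows that the number responds to the aryl group here, so this position joins the group on the sulfonyl sulfur as a second place where a change has moved the number beyond the scatter. Nothing available explains the rise.

This single swap changes the ring and adds a hydroxyl and a nitro group all at once, so it cannot show which of these changes accounts for the step from compound 1 to compound 3. A plain phenyl, a 4-hydroxyphenyl or a phenyl bearing an amine or a carboxylic acid in place of the nitro group would begin to separate those parts, and the compounds shown also leave open whether any aryl group here can bring a lower number than the 3-methylthiophen-2-yl of compound 1.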